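Lengthening the Side Chain of Compound 1

This account rests on a few compounds, and the source may have more. Where it says the series, first, only, none or still open, it means among the compounds named here.

Compound 1, `COc1c(C)c(C/C=C(\C)CCC=C(C)C)c(OC)c(OC)c1OC`, was tested in an assay on cells for inhibition of Amine oxidase [flavin-containing] B (Homo sapiens), read by fluorescence, with stated times of 10 min and 20 min, tested at 25 uM (on this read-out lower numbers stand for less inhibition and higher numbers for more inhibition at the one concentration tested (going by the name of the read-out)), where compound 1 gives 38%. This is the lowest of the two numbers measured here. Compound 2, `CC(C)=CCC/C(C)=C/CC/C(C)=C/CC1=C(C)C(=O)C(O)=C(O)C1=O`, built on a different core, gives 93.1% in this assay; the two values lie far apart, beyond the usual scatter, but no single change connects compound 1 with compound 2, so the comparison only shows what the two numbers are.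

Compound 3, `COc1c(C)c(C/C=C(\C)CC/C=C(\C)CCC=C(C)C)c(OC)c(OC)c1OC`, is not yet measured. It differs from compound 1 in one place: 3-methylbut-2-en-1-yl in place of hydrogen on a saturated chain carbon bound to a double-bonded chain carbon. Within the data shown here, no measured pair shows what such a change does to this read-out, so the expectation rests on compound 1 alone. A modest rise is expected, with the step estimated at a number 8 percentage points higher from compound 1 to compound 3 (within the scatter), which may still lie within the scatter. Compound 3 is therefore expected to give about 46%, within a range from 26% to 66%.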

Compound 3, a percentage reported as inhibition, at one concentration (the size of the read-out at that concentration, not a potency): 15.2%
Estimate against measurement, compound 3: 30.8 percentage points above, and the stated range ends above it.
By their numbers in this assay, from the lowest: compound 3; then compound 1; then compound 2.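

In this assay, placing 3-methylbut-2-en-1-yl on a saturated chain carbon bound to a double-bonded chain carbon gives a number 22.8 percentage points lower from compound 1 to compound 3 (beyond the scatter), so on this shared core the longer side chain goes with less inhibition, not more. Among these compounds, as the only one-place change here, it shows that the read-out responds to this change in chain length: 3-methylbut-2-en-1-yl growing to 3,7-dimethylocta-2,6-dien-1-yl moves the number beyond the usual scatter. No measurement shown here bears on why the number falls.

A single step cannot tell whether inhibition would keep falling with a still longer chain. Also open, going by these compounds, is how an amine or a carboxylic acid in place of the 3-methylbut-2-en-1-yl would read, and whether the same lengthening would change compound 2 from its 93.1% in this read-out.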